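The compounds below may be only part of what the source reports. "The series", "measured", "known", "first", "only" and "open" are said of these compounds alone.

Compound 1 `Cn1cc(C2CC(c3ccc(Br)cc3)=NN2C(=O)c2cccnc2)c2cc(Br)ccc21` in a functional assay on HeLa cells (Homo sapiens) for inhibition, read by MTT assay, with a stated time of 48 h (a lower number here means a stronger inhibitor of growth, a higher number a weaker inhibitor of growth), gives > 10000 nM, which is a limit of the assay. Compound 2 `COc1ccc(C2=NN(C(=O)c3cccnc3)C(c3cn(C)c4ccc(Br)cc34)C2)cc1` gives 890 nM in this assay. Compound 3 `COc1ccc2c(c1)c(C1CC(c3ccc(Br)cc3)=NN1C(=O)c1ccc(OC)nc1)cn2C` gives > 10000 nM in this assay, again a limit.

The one measured step among these three is the change from compound 1 to compound 2, (methoxy in place of bromo on an aromatic carbon). It made an at least 11-fold lower number from compound 1 to compound 2 (1.05 log units; beyond the scatter). How the core of compound 1 differs from the core of compound 3 is not broken down here. Compound 4 `COc1ccc(C2=NN(C(=O)c3ccc(OC)nc3)C(c3cn(C)c4ccc(OC)cc34)C2)cc1` is not yet measured; it carries the same change relative to compound 3, (methoxy in place of bromo on an aromatic carbon), in the same place as before. For compound 3 only the limit of > 10000 nM in this assay, at which 2 of the 3 values shown sit, is known, so the starting point of the new step is itself uncertain. Compound 4 is expected to show an at least 5.0-fold lower number from compound 3 to compound 4 (0.69 log units; beyond the scatter) in this assay, because the same change gave an at least 11-fold lower number from compound 1 to compound 2 (1.05 log units; beyond the scatter). For compound 4 the estimate is 2000 nM with a range from 500 nM to 10000 nM in this assay.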

Compound 4, concentration for 50% growth inhibition: 180 nM
Beside the measured number, compound 4's estimate is 11-fold (1.05 log units) above it; the whole stated range lies above it.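

The change from 4-bromophenyl to 4-methoxyphenyl gave an at least 55-fold lower number from compound 3 to compound 4 (1.74 log units; beyond the scatter) in this assay, so on both cores shown it moves the number in the same direction: the same change on two cores in this assay, an at least 11-fold lower number (1.05 log units; beyond the scatter) from compound 1 to compound 2 and an at least 55-fold lower number (1.74 log units; beyond the scatter) from compound 3 to compound 4; the limit leaves it open whether they differ. Each of the two steps starts from a limit of the assay and not from a number: the limit of > 10000 nM in this assay, at which 2 of the 4 values shown sit. The result therefore shows that the change carried over from the core of compound 1 to the core of compound 3, but it does not show the true size of either step or whether the change is worth more on one core than on the other, and two cores cannot show that it would hold across the wider series.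

On these data alone, only bromo and methoxy appear at this place, so it stays open how a hydroxy group, an amine or a longer chain such as ethoxy would read there in this assay. As far as these compounds go, it also stays open whether the change would go the same way on a core that carries an amine or a carboxylic acid.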